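Swapping a Nitro for a Methoxy in Compound 4

A few compounds are considered here, and "the series" means these few. Any claim that something is new, unique, unknown or untested is made for them only; others in the source may bear on it.

Of the compounds shown here, three have been measured in a functional assay on HeLa cells (Homo sapiens) for inhibition, read by MTT assay, with a stated time of 72 h; a lower number here means a stronger inhibitor, a higher number a weaker inhibitor. Compound 1 `COc1cc(OC)c(OC)cc1/C=C/C(=O)c1cc(Cc2ccccc2)cc(Cc2ccccc2)c1` gives 26900 nM, and compound 2 `COc1cc(OC)c(C(=O)/C=C/c2cc(OC)c(OC)cc2OC)c(OC)c1` gives 108000 nM. Compound 3 `COc1cc(OC)c(OC)cc1/C=C/C(=O)c1ccc([N+](=O)[O-])cc1` returns no number at all in this assay but only a limit, > 150000 nM, which is the limit of > 150000 nM in this assay, at which 1 of the 3 values shown sits. So compound 3 stands at the weak end of what is shown, with its true value unknown.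

Compound 4 `COc1ccc(C(=O)/C=C/c2cc(OC)c(OC)cc2OC)cc1` is still unmeasured. It differs from compound 3 by methoxy in place of nitro on an aromatic carbon. For the measured compounds named here, no step between two measured compounds is available to calibrate this change, and because compound 3 sits at the limit of > 150000 nM in this assay, at which 1 of the 3 values shown sits, the size of the step cannot be anchored from that side either. Going by the values given here, the only numbers known, from compound 1 and compound 2, are both weak, and nothing in the data suggests compound 4 will be much stronger. Compound 4 is therefore expected to give about 60000 nM, somewhere between 15000 nM and 150000 nM. This amounts to an expected step of an at least 2.5-fold lower number from compound 3 to compound 4 (0.39 log units; beyond the scatter) toward stronger inhibition, possibly no more than the scatter, with a fair chance that this assay again reports only a limit.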

Compound 4, half-maximal inhibitory concentration: 37600 nM
Estimate against measurement, compound 4: 1.6-fold (0.20 log units) above; the range from low to high includes it.
By their numbers in this assay, from the lowest: compounds 1 and 4 (each within the scatter of the next); then compound 2. At a limit, above all of these: compound 3.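

In this assay, methoxy in place of nitro on an aromatic carbon, para to a large group, brings an at least 3.9-fold lower number from compound 3 to compound 4 (0.60 log units; beyond the scatter). For the compounds shown here, this is the first step that can be read at this position, and because it lies beyond the scatter, it shows that the choice of group here changes the read-out, with methoxy giving the stronger inhibition of the two. Its full size stays unknown because compound 3 gives only a limit, so the step is a minimum: the limit of > 150000 nM in this assay, at which 1 of the 4 values shown sits.

With only nitro and methoxy shown at this position, it remains open whether methoxy itself helps or nitro simply hinders. An amine or a carboxylic acid on the same carbon would test this and show how far the number can move.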